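The source may hold more compounds than are shown below. What is called first, only, known or untested is meant among the compounds shown, and "the series" means these compounds.

Working notes on the series in a functional assay on MGC-803 cells (Homo sapiens) for cytotoxicity, read by MTT assay, with a stated time of 48 h; on this read-out lower numbers stand for stronger inhibition and higher numbers for weaker inhibition.

Among the measured compounds shown here, compound 1, `CC1=NN(S(=O)(=O)c2ccc(C)cc2)C(c2cc(Br)ccc2O)C1`, is the only member with a numerical result: in this assay compound 1 gives 30700 nM, a weak effect on this read-out. Compound 2, `O=C(CNC1CC1)N1N=C(c2cc3ccccc3oc2=O)CC1c1ccccc1`, shares no core with compound 1, so the two are not compared as a step. In this assay compound 2 is reported as "not active" (no number reported), with no number attached; it therefore stands without a position on the scale, and nothing can be said of its distance from compound 1.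

Compound 3, `O=C(CN1CCC(O)CC1)N1N=C(c2cc3ccccc3oc2=O)CC1c1ccccc1`, is compound 2 with one change: 4-hydroxypiperidin-1-yl in place of cyclopropylamino on a saturated chain carbon bound to a carbonyl carbon. For the measured compounds named here, both substituents are saturated amines on the same chain carbon; the only measured point to anchor the new compound is the inactivity of compound 2, and no step between measured compounds exists to show how changes at this position move the result. The expectation is therefore no movement beyond the scatter, with a real chance that compound 3 again returns only a limit rather than a number.

Compound 3 is estimated at 40000 nM in this assay, within a range of 8000 nM to 200000 nM.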

Compound 3, half-maximal inhibitory concentration: "not active" (no number reported)
For compound 3 the study gives words and no number, so the estimate cannot be set against anything.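

In this assay compound 2 and compound 3 are both reported in words without a number, so no step can be read for the change from cyclopropylamino to 4-hydroxypiperidin-1-yl. The compounds shown leave open whether any group at this place, on a saturated chain carbon bound to a carbonyl carbon, gives a numerical result. No evidence bears on these results.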